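The source may hold more compounds than are shown below. What is called first, only, known or untested is meant among the compounds shown, and "the series" means these compounds.

Among the measured compounds shown here, compound 2, with the structure `COc1ccc(C(=O)Nc2cccc(NC(=O)COc3ccc4c(=O)ccoc4c3)c2)cc1`, is tested in an assay on isolated protein for inhibition of Rho-associated protein kinase 1 (Homo sapiens), read by scintillation counting, radiometric assay and 33P incorporation, with a stated time of 40 min, in the presence of a further agent that is not named here (on this read-out higher numbers stand for weaker inhibition and lower numbers for stronger inhibition), and gives 18 nM, the only actual number among the two measured compounds. Compound 1, with the structure `Cc1c(OCC(=O)Nc2cccc(NC(=O)c3ccc(N(C)C)cc3)c2)ccc2c(=O)ccoc12`, reaches only a limit of the assay, > 10000 nM, so no number stands for it. Compound 3, with the structure `Nc1cccc(C(=O)Nc2cccc(NC(=O)COc3ccc4c(=O)ccoc4c3)c2)c1`, has not yet been measured; it differs from compound 2 in one place: 3-aminophenyl in place of 4-methoxyphenyl on a carbonyl carbon. For the measured compounds named here, no measured pair differs in this way, so the size of the step is open. Compound 3 is expected to stay close to compound 2, with the step of a 1.7-fold higher number from compound 2 to compound 3 (0.22 log units; within the scatter) judged to lie within the usual scatter. Compound 3 is therefore estimated at 30 nM, between 8 nM and 120 nM.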

Compound 3, half-maximal inhibitory concentration: 670 nM
Compound 3: the middle estimate sits 22-fold (1.35 log units) below what was measured; the whole stated range lies below it.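

Even with the rest of the molecule unchanged, this carbonyl carbon does not tolerate every aryl group: 3-aminophenyl in place of 4-methoxyphenyl gives a 37-fold higher number from compound 2 to compound 3 (1.57 log units; beyond the scatter) in this assay. Two substituted phenyl rings of similar size can therefore differ widely here. Nothing shown gives a reason for the size of this step.

Still open, as far as these compounds go, is whether the step comes from losing the methoxy group, gaining the amine, or the group's place on the ring. An unsubstituted phenyl on the same carbonyl carbon would help to separate these.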